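Triazole in place of a hydrogen at the anomeric methoxy

The source may report more compounds than this note shows. Statements on the series, on what has been measured and on what is new or still open speak of the compounds shown alone.

Compound 1 `CO[C@]1(C(=O)O)C[C@H](O)[C@@H](NC(C)=O)[C@H]([C@@H](O)[C@H](O)CNC(=O)c2ccccc2)O1`: 137000 nM
Compound 2 `COCC(=O)N[C@H]1[C@H]([C@@H](O)[C@H](O)CNC(=O)c2ccc(Cl)cc2)O[C@@](OCc2cccc(F)c2F)(C(=O)O)C[C@@H]1O`: 2300 nM

In an in vitro assay on cells for binding affinity to myelin-associated glycoprotein (Mus musculus), read by surface plasmon resonance (a higher number here means weaker binding, a lower number tighter binding), compound 1 gives the higher of the two numbers; compound 2, which differs from it in several places, gives 2300 nM. Compound 3 `CC(=O)N[C@H]1[C@H]([C@@H](O)[C@H](O)CNC(=O)c2ccccc2)O[C@@](OCc2c[nH]nn2)(C(=O)O)C[C@@H]1O` is not yet measured. It is obtained from compound 1 by this change: 1H-1,2,3-triazol-4-yl in place of hydrogen on a saturated chain carbon bound to an oxygen on a saturated carbon. Within the data shown here, no single-change step is available to anchor this move, so the expectation rests on the spread between the two measured values. The step of a 5.5-fold lower number from compound 1 to compound 3 (0.74 log units; beyond the scatter) is expected to run toward tighter binding, beyond the scatter. Compound 3 is estimated at 25000 nM, within 5000 nM to 100000 nM.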

Compound 3, dissociation constant: 11700 nM
The estimate for compound 3 lay 2.1-fold (0.33 log units) above the measured number; the measured number falls inside the stated range.
By their numbers in this assay, from the lowest: compound 2; then compound 3; then compound 1.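

Changing the methoxy of compound 1 to the (1H-1,2,3-triazol-4-yl)methoxy of compound 3 gives a 12-fold lower number from compound 1 to compound 3 (1.07 log units; beyond the scatter) in this assay. Among these compounds, this is the first step between compounds differing in one place, and it shows that this position accepts the added ring with tighter binding while the rest of the core stays unchanged. Nothing measured here explains the gain.

Going by these compounds, it remains open whether a phenyl ring, a 1-methyl-1H-1,2,3-triazol-4-yl group or a longer chain in the same place would give a similar step. On these data alone, it is also open whether this step would hold alongside the chloro substituent on the benzamide.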